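A few compounds are considered here, and "the series" means these few. Any claim that something is new, unique, unknown or untested is made for them only; others in the source may bear on it.

The account concerns two measured compounds and one untested analogue built on the same core. Compound 1 `O=C(CN(c1nc(Cl)nc2[nH]cnc12)C1CC1)N[C@@H](CC(=O)OCc1ccccc1)C(=O)OCc1ccccc1` carries two benzyloxycarbonyl groups, while compound 2 `O=C(O)C[C@H](NC(=O)CN(c1nc(Cl)nc2[nH]cnc12)C1CC1)C(=O)O` carries neither of them. In a functional assay on the whole organism (Tail, strain ICR) with Mus musculus as the target, in the tail flick test, with a stated time of 30 min, at a dose of 25 umol/kg by the oral route (on this read-out lower numbers stand for a weaker effect and higher numbers for a stronger effect at the one dose given), compound 1 gives 34.7%, and in this assay compound 2 gives 19.9%. Compound 1 thus stands highest of the two numbers, with compound 2 lower by a gap beyond the usual scatter of such measurements. Compound 3 `NC(=O)C[C@H](NC(=O)CN(c1nc(Cl)nc2[nH]cnc12)C1CC1)C(=O)OCc1ccccc1` differs from compound 1 in a single place: amino in place of benzyloxy on a carbonyl carbon. The second benzyloxycarbonyl group of compound 1 is kept in compound 3. For the measured compounds named here, no measured pair shows this exact change, so any expectation rests on what compound 1 and compound 2 show, namely that the compound without benzyloxy groups gave the lower number. Since compound 3 exchanges only one of them, a modest decrease relative to compound 1 is expected, and the estimated step from compound 1 to compound 3 is a number 6.7 percentage points lower from compound 1 to compound 3 (within the scatter). Compound 3 is therefore expected to reach about 28%, in an estimated range from 15% to 42%.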

Compound 3, a percentage reported as activity, at one dose (the size of the read-out at that dose, not a potency): 24.4%
The estimate for compound 3 lay 3.6 percentage points above the measured number, within the range that was stated.
By their numbers in this assay, from the lowest: compounds 2 and 3 (each within the scatter of the next); then compound 1.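

In this assay, exchanging benzyloxy for amino on a carbonyl carbon whose other neighbour is a saturated chain carbon gives a number 10.3 percentage points lower from compound 1 to compound 3 (beyond the scatter). Compound 1 and compound 2 differ in more than one place, so they could not show what a single place contributes; this step shows that a change at this one position, with the second benzyloxycarbonyl group kept, is enough to move the read-out beyond the scatter, although the step is modest. Nothing shown accounts for why the read-out falls with this change.

The compounds shown leave open whether the step follows the departure of benzyloxy with its aromatic ring or the arrival of amino, and whether a methoxy group, a dimethylamino group or the hydroxyl of a carboxylic acid on this carbonyl carbon would read closer to compound 1 or to compound 3. They also leave open whether the same exchange on the second benzyloxycarbonyl group, taken alone, would give a step of similar size.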